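A few compounds are considered here, and "the series" means these few. Any claim that something is new, unique, unknown or untested is made for them only; others in the source may bear on it.

Measured compounds:
compound 1, `CCc1c(CC)c(OC(C)=O)c2c(C)c(C)cc(C)c2c1OC`: 15700 nM in a functional assay for inhibition, with Rattus norvegicus as the target; on this read-out lower numbers stand for stronger inhibition and higher numbers for weaker inhibition
compound 2, `CCc1c(CC)c(OC(C)=O)c2c(C)c(C)c(C)c(C)c2c1OC`: 37300 nM in this assay
compound 3, `CCCCc1c(C)c(OC)c2c(ccn2C)c1OC(C)=O`: 760 nM in this assay

Of these three, compound 3 gives the lowest number, and its gaps to compound 1 and to compound 2 both lie beyond the scatter. Compound 3 and compound 2 rest on different cores, and the difference between the two cores is not broken down here.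

Within the core shared by compound 1 and compound 2, one change is measured: from compound 2 to compound 1 the change is hydrogen in place of methyl on an aromatic carbon and the result is a 2.4-fold lower number from compound 2 to compound 1 (0.38 log units; beyond the scatter).

The unmeasured compound 4, `CCCCc1cc(OC)c2c(ccn2C)c1OC(C)=O`, is derived from compound 3 by the same kind of change, (hydrogen in place of methyl on an aromatic carbon). The surroundings are not the same, however: in the measured pair the carbon is ortho to two methyl groups and meta to a methyl group, whereas in compound 3 it is ortho to a butyl group, ortho to a methoxy group and meta to an acetoxy group. It is therefore the same kind of change rather than the same change.

For compound 4 a step of a 1.5-fold lower number from compound 3 to compound 4 (0.18 log units; within the scatter) is expected in this assay, which rests on the step seen from compound 2 to compound 1, a 2.4-fold lower number from compound 2 to compound 1 (0.38 log units; beyond the scatter). The changed carbon sits among different neighbours in compound 3 than in the measured pair, so this transfer is read with caution. In this assay compound 4 is accordingly estimated at 500 nM, with the expected range running from 200 nM to 1500 nM.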

Compound 4, half-maximal inhibitory concentration: 720 nM
Compound 4: middle estimate off by 1.4-fold (0.16 log units), on the low side, within the range that was stated.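

On the core of compound 3, hydrogen in place of methyl on the aromatic carbon ortho to a butyl group and ortho to a methoxy group gives a 1.1-fold lower number from compound 3 to compound 4 (0.02 log units; within the scatter) in this assay, so on this core the exchange leaves the read-out within the usual scatter. Set beside the same exchange on the core of compound 1 and compound 2, the two steps can be read as compatible with one another, even though only the earlier one lies beyond the scatter on its own: the same change on two cores in this assay, a 2.4-fold lower number (0.38 log units; beyond the scatter) from compound 2 to compound 1 and a 1.1-fold lower number (0.02 log units; within the scatter) from compound 3 to compound 4, 2.3-fold (0.35 log units) apart, within the scatter of two such steps This shows that nothing in these two pairs speaks against carrying the change from one core to the other, but it does not show that the step has one fixed size across cores, since two pairs on cores with different neighbours around the changed carbon cannot separate a small real difference from scatter.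

The compounds shown leave open what happens when that aromatic carbon carries something other than methyl or hydrogen, such as a chlorine atom, an amine or a longer chain. They also leave open whether the result would hold on either core with a hydroxyl group in place of the acetoxy group.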